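The source may hold more compounds than are shown below. What is called first, only, known or untested is meant among the compounds shown, and "the series" means these compounds.

Measured compounds:
- compound 1 `CN(C(=O)NC(=O)c1c(F)cccc1F)c1nc(C(F)(F)F)c(C(=O)N/N=C/c2cccc(C(F)(F)F)c2)s1`: 27.9 ug/mL
- compound 2 `CN(C(=O)NC(=O)c1ccc([N+](=O)[O-])cc1)c1nc(C(F)(F)F)c(C(=O)N/N=C/c2ccc([N+](=O)[O-])cc2)s1`: 12.3 ug/mL
- compound 3 `CN(C(=O)NC(=O)c1ccc(C(F)(F)F)cc1)c1nc(C(F)(F)F)c(C(=O)N/N=C/c2cccc(C(F)(F)F)c2)s1`: 7.95 ug/mL

All three share one core and differ in the aryl groups on the two arms. In a functional assay on HepG2 cells (Homo sapiens) for inhibition, read by MTT assay, with a stated time of 72 h (on this read-out lower numbers stand for stronger inhibition and higher numbers for weaker inhibition), compound 3 gives the lowest of the three numbers. Among the compounds with values here, compound 2 sits nearest, within the scatter of compound 3, so no order can be read between those two; compound 1 sits furthest, and the step of a 3.5-fold lower number from compound 1 to compound 3 (0.55 log units; beyond the scatter) is the only one-place change among the measured compounds, a modest move beyond the scatter that comes with a 4-(trifluoromethyl)phenyl in place of a 2,6-difluorophenyl on a carbonyl carbon.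

Compound 4 `CN(C(=O)NC(=O)c1ccc([N+](=O)[O-])cc1)c1nc(C(F)(F)F)c(C(=O)N/N=C/c2cccc(C(F)(F)F)c2)s1` is not yet measured. It differs from compound 3 by nitro in place of trifluoromethyl on an aromatic carbon. Within the data shown here, no measured step covers exactly this exchange. Compound 2, which carries nitro on both arms, and compound 3 differ in two places, and their two values lie within the scatter of each other, which is the closest guide available. Among the measured compounds shown here, the one measured step at the carbonyl carbon was modest in size, and a nitro for trifluoromethyl swap at the same place is expected to give no step beyond the scatter in this assay, an expected step of a 1.3-fold higher number from compound 3 to compound 4 (0.10 log units; within the scatter). Compound 4 is therefore estimated at 10 ug/mL, with a range from 5 ug/mL to 20 ug/mL.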

Compound 4, half-maximal inhibitory concentration: 4.73 ug/mL
Compound 4: the middle estimate sits 2.1-fold (0.33 log units) above what was measured; the whole stated range lies above it.
By their numbers in this assay, from the lowest: compounds 4, 3 and 2 (each within the scatter of the next, the first and the last beyond it); then compound 1.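

On the aromatic carbon para to a large group in the carbonyl arm, nitro in place of trifluoromethyl gives a 1.7-fold lower number from compound 3 to compound 4 (0.23 log units; within the scatter) in this assay and so sets no order between the two groups at this place. With a 5.9-fold lower number from compound 1 to compound 4 (0.77 log units; beyond the scatter) on replacing 2,6-difluorophenyl with 4-nitrophenyl on the carbonyl carbon, the earlier step away from 2,6-difluorophenyl is no longer confined to 4-(trifluoromethyl)phenyl, since both replacements now lie beyond the scatter. The earlier compounds shown here held no one-place step on the other arm, and a 2.6-fold lower number from compound 2 to compound 4 (0.42 log units; beyond the scatter) now shows that this arm also responds when 3-(trifluoromethyl)phenyl stands in place of 4-nitrophenyl on the carbon with a double bond to nitrogen.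

Nothing at hand bears on the reason for these steps.

From the compounds shown here alone, it remains open whether an amine or a carboxylic acid on the same aromatic carbon would stay within the scatter of nitro and trifluoromethyl. Also open, going by these compounds, is whether the step on the arm with the double bond to nitrogen keeps its size when the carbonyl arm carries a group other than 4-nitrophenyl.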